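A few compounds are considered here, and "the series" means these few. Any claim that something is new, unique, unknown or untested is made for them only; others in the source may bear on it.

Series notes. Compound 1 `Cc1ccccc1S(=O)(=O)Nc1ccc2oc(-c3ccccc3)nc2c1` and compound 2 `O=S(=O)(Nc1ccc2oc(-c3ccccc3)nc2c1)c1ccc(Cl)cc1` share one core and differ only in the aryl group on the sulfonyl sulfur. In an assay on isolated protein for inhibition of malate dehydrogenase, mitochondrial (Sus scrofa), with stated times of 45 min and 30 min (on this read-out lower numbers stand for stronger inhibition and higher numbers for weaker inhibition), compound 1 gives > 63000 nM, which is a limit of the assay and not a number. In this assay compound 2 gives > 63000 nM, likewise a limit and not a number. The step that the two limits leave unreadable from compound 1 to compound 2 is therefore of unreadable size, since both values sit at the limit of > 63000 nM in this assay, at which 2 of the 2 values shown sit. Compound 2 thus stands at the limit on every number shown for it, with no measured value placing it anywhere within the readable range.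

Compound 3 `O=S(=O)(Nc1ccc2oc(-c3ccccc3)nc2c1)c1ccccc1Cl` is the next member, and it differs from compound 2 by 2-chlorophenyl in place of 4-chlorophenyl on a sulfonyl sulfur. For the measured compounds named here, no measured step bears directly on this change, and the one measured step is unreadable because the limit of > 63000 nM in this assay, at which 2 of the 2 values shown sit, is all either of its compounds shows. Nothing in the data points to a readable gain, so the expected step that the limit leaves unreadable from compound 2 to compound 3 is none beyond the scatter and a further limit is the likelier outcome. Compound 3 is estimated at 100000 nM, with a range from 40000 nM to 300000 nM.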

Compound 3, half-maximal inhibitory concentration: > 63000 nM
Compound 3 ended at the assay's limit (the forecaster's own chance of this, stated with the estimate: 85%); the middle value is on the limit's open side.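

In this assay compound 3 gives > 63000 nM, a limit of the assay and not a number. For the compounds shown here, no step among compound 1, compound 2 and compound 3 can be read: the limit of > 63000 nM in this assay, at which 3 of the 3 values shown sit. The compounds shown leave open how 2-methylphenyl, 4-chlorophenyl and 2-chlorophenyl on the sulfonyl sulfur rank against one another.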